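The compounds below may be only part of what the source reports. "The series", "measured", "known", "first", "only" and "open" are said of these compounds alone.

Measured in an ADME assay on HeLa cells (Homo sapiens) for cytotoxicity, read by MTT assay, with a stated time of 72 h; a lower number here means that less compound is tolerated, a higher number that more compound is tolerated:

- compound 1 `Nc1sc2c(c1-c1nc3cc(Cl)ccc3s1)CCCC2` gives 107 ug/mL
- compound 2 `Clc1ccc(/C=N/c2sc3c(c2-c2nc4ccccc4s2)CCC3)c(Cl)c1` gives 345 ug/mL
- compound 3 `Clc1ccc(/C=N/c2sc3c(c2-c2nc4ccccc4s2)CCCC3)cc1` gives 431 ug/mL

Compound 3 holds the highest of the three numbers in this assay. Its nearest neighbour is compound 2, whose number sits within the usual scatter of it, so no order between these two can be read. The only gap that stands beyond the scatter is to compound 1, which tolerates a lower number; compound 1 differs from compound 3 in more than one place, so nothing is attributed to any single change there.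

Compound 4 `Clc1ccccc1/C=N/c1sc2c(c1-c1nc3ccccc3s1)CCCC2` is the next member. Against compound 3 the difference is 2-chlorophenyl in place of 4-chlorophenyl on a carbon with a double bond to nitrogen. Among the measured compounds shown here, no pair among the measured compounds isolates a change of this kind, so there is nothing in this assay to anchor the size of the step. Given that compounds 2 and 3 lie within the scatter of one another despite differing elsewhere, the expected step is a 1.1-fold lower number from compound 3 to compound 4 (0.05 log units; within the scatter), none beyond the scatter, in this assay. Compound 4 is expected to give 380 ug/mL, with a range from 170 ug/mL to 850 ug/mL.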

Compound 4, half-maximal cytotoxic concentration: 407 ug/mL
Compound 4: the middle estimate sits 1.1-fold (0.03 log units) below what was measured, within the range that was stated.
By their numbers in this assay, from the lowest: compound 1; then compounds 2, 4 and 3 (each within the scatter of the next).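

In this assay the series now has its first pair differing in one place: 2-chlorophenyl in place of 4-chlorophenyl on a carbon with a double bond to nitrogen gives a 1.1-fold lower number from compound 3 to compound 4 (0.02 log units; within the scatter), so no order can be read between the two compounds. At this position, therefore, exchanging one chlorophenyl isomer for the other, with the same atoms and the same counts of donors and acceptors, produces no readable change in this assay; this holds for this single pair only and says nothing yet about other groups at the same place. No measurement at hand bears on this result, and it offers no account of it.

From the compounds shown here alone, whether an unsubstituted phenyl, or a phenyl carrying a carboxylic acid or an amine, in place of 4-chlorophenyl on a carbon with a double bond to nitrogen would give a step beyond the scatter stays open. Compound 1 at 107 ug/mL still has no partner differing from it in one place, so its standing in the series cannot be assigned to any single feature.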